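A few compounds are considered here, and "the series" means these few. Any claim that something is new, unique, unknown or untested is made for them only; others in the source may bear on it.

Measured in a functional assay on A549 cells (Homo sapiens) for antiproliferative activity, read by MTT assay, with a stated time of 72 h; on this read-out lower numbers stand for stronger inhibition and higher numbers for weaker inhibition:
- compound 1 `COc1cc(C(=O)c2sc3ccccc3c2-c2ccc(Cl)cc2)cc(OC)c1OC`: 7500 nM
- compound 2 `COc1ccc(-c2c(C(=O)c3cc(OC)c(OC)c(OC)c3)sc3ccccc23)cc1`: 4400 nM
- compound 3 `COc1ccc(-c2c(C(=O)c3cc(OC)c(OC)c(OC)c3)sc3ccccc23)c(OC)c1`: 5800 nM

Compound 3, at 5800 nM, cannot be separated from the other two compounds, since both of its steps lie within the scatter: a 1.3-fold lower number from compound 1 to compound 3 (0.11 log units; within the scatter) and a 1.3-fold higher number from compound 2 to compound 3 (0.12 log units; within the scatter).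

The next change leads to compound 4 `CCOc1ccc(-c2c(C(=O)c3cc(OC)c(OC)c(OC)c3)sc3ccccc23)cc1`, with 4-ethoxyphenyl in place of 2,4-dimethoxyphenyl on an aromatic carbon of a five-membered aromatic ring with 1 sulfur (4-ethoxyphenyl in place of 2,4-dimethoxyphenyl on an aromatic carbon).

For the measured compounds named here, three measured steps bear on this change. The closest is the one that adds methoxy in place of hydrogen on an aromatic carbon, a 1.3-fold higher number from compound 2 to compound 3 (0.12 log units; within the scatter), and compound 4 again lacks that second methoxy. The exchange of methoxy for chloro, a 1.7-fold lower number from compound 1 to compound 2 (0.23 log units; within the scatter), is also within the scatter, as is the exchange of the whole aromatic group, a 1.3-fold lower number from compound 1 to compound 3 (0.11 log units; within the scatter). No change among these three compounds has yet moved the number beyond the scatter, although an ethoxy group has not been measured here.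

The expected change is no more than the scatter, with an estimated 1.2-fold lower number from compound 3 to compound 4 (0.06 log units; within the scatter). For compound 4 the estimated value is 5000 nM, with an expected range from 2300 nM to 10000 nM.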

Compound 4, half-maximal inhibitory concentration: 3100 nM
The estimate for compound 4 lay 1.6-fold (0.21 log units) above the measured number, and the stated range covers the measured number.
By their numbers in this assay, from the lowest: compounds 4, 2, 3 and 1 (each within the scatter of the next, the first and the last beyond it).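

In this assay, for the compounds shown here, the exchange of chloro for ethoxy on an aromatic carbon gives the first step in this set that lies beyond the scatter, though a modest one (a 2.4-fold lower number from compound 1 to compound 4 (0.38 log units; beyond the scatter)). The two neighbouring changes stay within the scatter: 4-ethoxyphenyl in place of 2,4-dimethoxyphenyl (a 1.9-fold lower number from compound 3 to compound 4 (0.27 log units; within the scatter)) and the added methyl on the saturated chain carbon bound to the oxygen (a 1.4-fold lower number from compound 2 to compound 4 (0.15 log units; within the scatter)), so compound 4 cannot be separated from compound 2 or compound 3, and only the comparison with compound 1 shows a difference at this position on the ring bearing the sulfur. Nothing on hand accounts for any of these differences.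

Open, on these data alone, is whether a longer chain on the oxygen, such as propoxy or butoxy, would carry the number further from that of compound 1 or leave it within the scatter of compound 4. Also open, as far as these compounds go, is how a group of another kind in the same place, such as a dimethylamino group, a hydroxy group or a carboxylic acid, would compare with 4-ethoxyphenyl on this read-out.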